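Aryl swap on the piperazine of the aminothiophene ketone series

This account rests on a few compounds, and the source may have more. Where it says the series, first, only, none or still open, it means among the compounds named here.

Two members of the series have been read so far. Compound 2 `Nc1scc(CN2CCN(c3cccnc3)CC2)c1C(=O)c1ccc(Cl)cc1` gives 3.2% in a functional assay on CHO cells with adenosine receptor A1 (Homo sapiens) as the target, read by cAMP accumulation and immunoassay, with a stated time of 6 min, tested at 0.01 uM (a higher number here means a weaker effect of the compound at the concentration tested, a lower number a stronger effect), the higher of the two numbers in hand. Going by the values given here, compound 1 `Nc1scc(CN2CCN(c3ccc(Cl)cc3F)CC2)c1C(=O)c1ccc(Cl)cc1` gives -9.2% in this assay, and the only step between measured compounds, a number 12.4 percentage points higher from compound 1 to compound 2 (beyond the scatter), describes pyridin-3-yl in place of 4-chloro-2-fluorophenyl on an amine nitrogen in a ring. Compound 3 `Nc1scc(CN2CCN(c3ccc(Cl)c(Cl)c3)CC2)c1C(=O)c1ccc(Cl)cc1` is the next member to be read; relative to compound 2 the change is 3,4-dichlorophenyl in place of pyridin-3-yl on an amine nitrogen in a ring.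

The step from compound 1 to compound 2 is the only one that bears on this change, and it runs in the opposite sense: there a halogenated phenyl gave way to pyridin-3-yl and the number rose modestly. Returning a halogenated phenyl in place of pyridin-3-yl is therefore expected to move the number downward by a comparable amount, the expected step being a number 11.2 percentage points lower from compound 2 to compound 3 (beyond the scatter). Among the compounds with values here, compound 3 is estimated at -8% in this assay, with a range from -22% to 6%; the exact halogen pattern on the phenyl has no precedent in the two compounds measured, so the range is kept wide.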

Compound 3, a percentage reported as activity, at one concentration (the size of the read-out at that concentration, not a potency): -1.2%
For compound 3 the middle estimate is 6.8 percentage points below the measured one, and the stated range covers the measured number.
By their numbers in this assay, from the lowest: compounds 1, 3 and 2 (each within the scatter of the next, the first and the last beyond it).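

In this assay, a halogenated phenyl in place of pyridin-3-yl on the amine nitrogen in the ring does not by itself give a step beyond the scatter: there is a number 4.4 percentage points lower from compound 2 to compound 3 (within the scatter), whereas the other halogenated phenyl was separated from pyridin-3-yl by a number 12.4 percentage points higher from compound 1 to compound 2 (beyond the scatter). The two halogen patterns are not told apart either, with a number 8 percentage points higher from compound 1 to compound 3 (within the scatter), so compound 3 cannot be grouped with either end of the set, and the only gap beyond the scatter remains the one between 4-chloro-2-fluorophenyl and pyridin-3-yl. No measurement in hand accounts for why that single pair separates while the two steps involving 3,4-dichlorophenyl do not.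

Open, on these data alone, is whether the fluorine-bearing phenyl or the pyridine nitrogen drives that one separation, which an unsubstituted phenyl or a 4-chlorophenyl on the same amine nitrogen would help to settle. All three readings also come from one concentration, so they give the size of the read-out there and leave any ranking by potency across these aryl groups unresolved.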